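This account rests on a few compounds, and the source may have more. Where it says the series, first, only, none or still open, it means among the compounds named here.

In a functional assay on HT-29 cells (Homo sapiens) for antiproliferative activity (on this read-out lower numbers stand for stronger inhibition and higher numbers for weaker inhibition), compound 1 (`COc1ccc(S(=O)(=O)N2CCc3cccc(Nc4ccc(Cl)cc4)c32)cc1`) gives 658 nM, compound 2 (`COc1ccc(S(=O)(=O)N2CCc3cccc(Nc4ccc(F)c(F)c4)c32)cc1`) gives 968 nM, and compound 3 (`COc1ccc(S(=O)(=O)N2CCc3cccc(Nc4ccc(C#N)cc4)c32)cc1`) gives 149 nM, the lowest of the three numbers. Compound 4 (`COc1ccc(S(=O)(=O)N2CCc3cccc(Nc4ccc(C(=O)O)cc4)c32)cc1`) has not yet been measured. It differs from compound 3 as follows: carboxy in place of cyano on an aromatic carbon. Within the data shown here, two measured steps bear on this change: a 4.4-fold lower number from compound 1 to compound 3 (0.65 log units; beyond the scatter) and a 6.5-fold lower number from compound 2 to compound 3 (0.81 log units; beyond the scatter). Both reach a nitrile, and none involves a carboxy group, so they are only a rough guide. Since the step of a 4.4-fold lower number from compound 1 to compound 3 (0.65 log units; beyond the scatter) shows a chloro group sitting higher than the cyano, replacing the cyano is expected to raise the number, probably by more than these modest steps. The expected change is a 10-fold higher number from compound 3 to compound 4 (1.00 log units; beyond the scatter). For compound 4 the estimated value is 1500 nM, with an expected range from 350 nM to 8000 nM.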

Compound 4, half-maximal inhibitory concentration: 2380 nM
Compound 4: the middle estimate sits 1.6-fold (0.20 log units) below what was measured; the measured number falls inside the stated range.
By their numbers in this assay, from the lowest: compound 3; then compounds 1 and 2 (each within the scatter of the next); then compound 4.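

In this assay carboxy in place of cyano gives a 16-fold higher number from compound 3 to compound 4 (1.20 log units; beyond the scatter) and is the largest step seen at this aromatic carbon, so the group placed here can matter more than the earlier, modest steps showed. The carboxy compound also trails the other two, with a 3.6-fold higher number from compound 1 to compound 4 (0.56 log units; beyond the scatter) and a 2.5-fold higher number from compound 2 to compound 4 (0.39 log units; beyond the scatter) leaving compound 4 the weakest of the four. Nothing measured here explains this loss of activity. On these data alone, whether a methyl ester or a primary amide on the same carbon would behave more like cyano or like carboxy remains open.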